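The source may hold more compounds than are shown below. What is called first, only, known or untested is meant among the compounds shown, and "the series" means these compounds.

Compound 1, `Brc1cccc2c1nnn2CC1CC1`, gives 70 nM in a functional assay on cells for positive allosteric modulation of metabotropic glutamate receptor 2 (Homo sapiens), read by fluorescence and calcium flux, with a stated time of 30 min; a lower number here means that less compound is needed, a higher number that more compound is needed for the effect. Compound 2, `FC(F)(F)c1cc(Br)c2nnn(CC3CC3)c2c1`, gives 140 nM in this assay. Compound 3, `Fc1cc(Br)c2nnn(CC3CC3)c2c1`, gives 70 nM in this assay.

Compound 3 stands level with compound 1 at the digits shown, the two together being the lowest of the three numbers; the only other step is a 2.0-fold lower number from compound 2 to compound 3 (0.30 log units; within the scatter). Compound 4, `COc1cc(Br)c2nnn(CC3CC3)c2c1`, differs from compound 3 in one place: methoxy in place of fluoro on an aromatic carbon. Within the data shown here, two measured steps bear on this position. The step of no change at the digits printed from compound 1 to compound 3 (within the scatter) and the step of a 2.0-fold higher number from compound 1 to compound 2 (0.30 log units; within the scatter) both show that swapping groups at this carbon leaves the number within the scatter. Compound 4 is therefore expected to show no change at the digits printed from compound 3 to compound 4 (within the scatter), an estimate of 70 nM with a range from 35 nM to 140 nM in this assay.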

Compound 4, half-maximal effective concentration: 730 nM
Compound 4: the middle estimate sits 10-fold (1.02 log units) below what was measured, and the stated range ends below it.
By their numbers in this assay, from the lowest: compounds 1, 3 and 2 (each within the scatter of the next); then compound 4.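

In this assay methoxy on this carbon breaks the earlier flat picture: there is a 10-fold higher number from compound 3 to compound 4 (1.02 log units; beyond the scatter) and a 10-fold higher number from compound 1 to compound 4 (1.02 log units; beyond the scatter) and also a 5.2-fold higher number from compound 2 to compound 4 (0.72 log units; beyond the scatter). So this carbon takes hydrogen, fluoro and trifluoromethyl with numbers within the scatter of one another, but it does not take every group equally. Methoxy alone among these groups brings an oxygen, yet one compound cannot show whether the oxygen itself matters. As far as these compounds go, whether a hydroxyl, an ethoxy or an amine here would track methoxy stays open. Nothing measured here gives a reason for the rise.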